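This account rests on a few compounds, and the source may have more. Where it says the series, first, only, none or still open, it means among the compounds named here.

Compound 2 `CC(C)c1ccccc1OS(=O)(=O)c1ccc(NC(=O)CCl)cc1` stands second highest of the three numbers in a functional assay on HT-1080 cells (Homo sapiens) for antiproliferative activity, read by sulforhodamine B assay, with a stated time of 48 h; a lower number here means a stronger inhibitor, a higher number a weaker inhibitor: compound 2 gives 1000 nM, compound 3 `O=C(CCl)Nc1ccc(S(=O)(=O)Oc2ccccc2I)cc1` gives 600 nM, and compound 1 `CC(=O)Nc1cccc(S(=O)(=O)Oc2ccccc2C(C)C)c1` gives 21000 nM. For the measured compounds named here, the one measured step, a 1.7-fold lower number from compound 2 to compound 3 (0.22 log units; within the scatter), changes an aromatic carbon and not the carbonyl carbon, so it does not bear on the change in hand. Compound 4 `CC(C)c1ccccc1OS(=O)(=O)c1ccc(NC(=O)NC2CCCC2)cc1` differs from compound 2 by cyclopentylamino in place of chloromethyl on a carbonyl carbon. Compound 1 differs from compound 2 in more than one place; compound 1 gives 21000 nM while compound 2 gives 1000 nM, which is the only hint available about altering the chloroacetyl part. Compound 4 is therefore expected to show a step of a 10-fold higher number from compound 2 to compound 4 (1.00 log units; beyond the scatter) toward a higher number, with wide uncertainty. The estimate for compound 4 is 10000 nM, range 2000 nM to 40000 nM.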

Compound 4, half-maximal inhibitory concentration: 3900 nM
The estimate for compound 4 lay 2.6-fold (0.41 log units) above the measured number, and the stated range covers the measured number.
By their numbers in this assay, from the lowest: compounds 3 and 2 (each within the scatter of the next); then compound 4; then compound 1.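

In this assay, for the compounds shown here, a 3.9-fold higher number from compound 2 to compound 4 (0.59 log units; beyond the scatter) gives the first one-place reading at this carbonyl carbon. The rise is modest, so activity persists without the chloromethyl group, even with cyclopentylamino carrying a ring and a hydrogen-bond donor in its place. Nothing measured accounts for the step. Still open, on these data alone, is whether the rise goes with the lost chlorine, the added nitrogen or the ring, which a plain methyl or an open-chain propylamino on this carbonyl carbon would help separate. As far as these compounds go, whether cyclopentylamino behaves alike with iodo in place of isopropyl is also open.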